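This account rests on a few compounds, and the source may have more. Where it says the series, first, only, none or still open, it means among the compounds named here.

Working notes on the amine variation. Three members share one core and differ only in the amine on the aromatic carbon: compound 1 `CCN1CCN(c2ncc3c(n2)CCN(C(=O)c2cc(Cc4n[nH]c(=O)c5ccccc45)ccc2F)C3)CC1`, compound 2 `O=C(c1cc(Cc2n[nH]c(=O)c3ccccc23)ccc1F)N1CCc2nc(N3CCCC3)ncc2C1` and compound 3 `CN(C)CCN(C)c1ncc2c(n1)CCN(C(=O)c1cc(Cc3n[nH]c(=O)c4ccccc34)ccc1F)C2`. In a functional assay on MDA-MB-231 cells (Homo sapiens) for inhibition, read by MTT assay, with a stated time of 48 h (a lower number here means a stronger inhibitor, a higher number a weaker inhibitor), compound 1 gives > 200000 nM, a limit of the assay and not a number. In this assay compound 2 gives > 200000 nM, again a limit. In this assay compound 3 gives > 200000 nM, also a limit. The steps a step that the two limits leave unreadable from compound 1 to compound 2, a step that the two limits leave unreadable from compound 1 to compound 3 and a step that the two limits leave unreadable from compound 2 to compound 3 therefore cannot be sized; the whole set is summed up by the limit of > 200000 nM in this assay, at which 3 of the 3 values shown sit. Compound 3 thus stands at the limit, with no number to separate it from compound 1 or compound 2.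

Compound 4 `CCN(CC)c1ncc2c(n1)CCN(C(=O)c1cc(Cc3n[nH]c(=O)c4ccccc34)ccc1F)C2` is the next member: diethylamino in place of (2-(dimethylamino)ethyl)(methyl)amino on an aromatic carbon, so the amine shrinks from 7 to 5 heavy atoms and loses one acceptor, with no ring in either group. Within the data shown here, the steps that bear on this change are a step that the two limits leave unreadable from compound 1 to compound 3 and a step that the two limits leave unreadable from compound 2 to compound 3, both unreadable because the limit of > 200000 nM in this assay, at which 3 of the 3 values shown sit, covers every value measured so far. No measured step gives a direction, and none has shown any amine at this position reaching a number in this assay. Compound 4 is accordingly expected at 300000 nM, within 100000 nM to 1000000 nM, most likely reported as a limit again. The step that the limit leaves unreadable from compound 3 to compound 4 is expected to be none beyond the scatter.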

Compound 4, half-maximal inhibitory concentration: > 200000 nM
Compound 4 was reported as a limit; the forecaster's own chance of this, stated with the estimate: 85%; the middle value does not contradict the limit.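

No new step can be read for compound 4 against compound 1, compound 2 or compound 3, because all four stand at a limit of the assay and not at a number: the limit of > 200000 nM in this assay, at which 4 of the 4 values shown sit.

The compounds shown leave open whether any amine on the shared core reaches a number in this assay, and how these four amines would rank against one another.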